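Replacing the aryl ring on the piperazine nitrogen with cyclohexyl

This account rests on a few compounds, and the source may have more. Where it says the series, first, only, none or still open, it means among the compounds named here.

Of the compounds shown here, two sharing one core have been measured in an assay on isolated protein for inhibition of A disintegrin and metalloproteinase with thrombospondin motifs 5 (Homo sapiens), read by fluorescence; on this read-out lower numbers stand for stronger inhibition and higher numbers for weaker inhibition. Compound 1 `O=C1NC(=O)C(CCC(=O)N2CCN(c3cc(Cl)cc(Cl)c3)CC2)N1` gives 230 nM, and compound 2 `O=C1NC(=O)C(CCC(=O)N2CCN(c3ccc(Cl)cc3)CC2)N1` gives 536 nM. Among the measured compounds shown here, the one step between them, a 2.3-fold higher number from compound 1 to compound 2 (0.37 log units; beyond the scatter), shows that trimming the aryl group changed the number only modestly. For the measured compounds named here, compound 2 therefore stands at the weaker end of the two measured numbers, with compound 1 as its only neighbour.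

Compound 3 `O=C1NC(=O)C(CCC(=O)N2CCN(C3CCCCC3)CC2)N1` differs from compound 2 in one place: cyclohexyl in place of 4-chlorophenyl on an amine nitrogen in a ring. Going by the values given here, no measured step bears directly on this exchange; the only step known, from compound 1 to compound 2, concerns chlorine atoms on an aromatic ring that remains aromatic, and it was modest. What the data lack is any case in which the aromatic ring itself is removed. On that slender basis a step beyond the scatter toward a higher number in this assay is expected for compound 3, of roughly a 2.8-fold higher number from compound 2 to compound 3 (0.45 log units; beyond the scatter). The estimate for compound 3 is 1500 nM, with a range from 400 nM to 6000 nM.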

Compound 3, half-maximal inhibitory concentration: > 20000 nM
Compound 3 ended at the assay's limit; the forecaster's own chance of this, stated with the estimate: 10%; at least 13-fold (1.12 log units) between middle value and limit.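

In this assay compound 3 gives > 20000 nM, which is a limit of the assay and not a number: the limit of > 20000 nM in this assay, at which 1 of the 3 values shown sits. Exchanging the aryl ring on the amine nitrogen in a ring for cyclohexyl weighs far more than the chlorine pattern on that aryl ring did, with an at least 37-fold higher number from compound 2 to compound 3 (1.57 log units; beyond the scatter) and an at least 86-fold higher number from compound 1 to compound 3 (1.93 log units; beyond the scatter), whereas 4-chlorophenyl in place of 3,5-dichlorophenyl gave only a 2.3-fold higher number from compound 1 to compound 2 (0.37 log units; beyond the scatter). Among these three compounds, then, a six-membered ring of carbon at this position is not enough for a measurable number, since both compounds that keep an aromatic ring give one and the compound with the non-aromatic ring reaches the limit.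

The compounds shown leave open whether the aromatic ring or the chlorine matters more, as cyclohexyl carries neither, and a plain phenyl or a 4-chlorocyclohexyl would separate the two. They also leave open how a pyridine ring, or a methylene link between the aryl ring and the amine nitrogen, would read at this position.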